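The source may report more compounds than this note shows. Statements on the series, on what has been measured and on what is new or still open speak of the compounds shown alone.

Measured compounds, maximal response in a functional assay on the whole organism (B cells) with Mus musculus as the target; a higher number here means a larger maximal response, a lower number a smaller maximal response:

- compound 1 `C=CCn1c(=O)n(C2C=CC(CO)O2)c2nc(N)nc(O)c21`: 45%
- compound 2 `Nc1nc(O)c2c(n1)n(C1OC(CO)[C@@H](O)[C@H]1O)c(=O)n2Cc1ccc(Cl)cc1`: 15%
- compound 3 `Cn1c(=O)n([C@@H]2O[C@H](CO)[C@H]3OC(C)(C)O[C@H]32)c2nc(N)nc(O)c21`: 193%

Compound 2 stands lowest of the three numbers. Compound 1 lies nearest, a number higher by a step beyond the scatter; compound 3 lies furthest, higher by a step well beyond the scatter. Going by the values given here, no pair among the measured compounds differs in a single place, so no single-point step is available to lean on.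

Compound 4 `[N-]=[N+]=NCC(O)Cn1c(=O)n(C2OC(CO)[C@@H](O)[C@H]2O)c2nc(N)nc(O)c21` is not yet measured. Against compound 2 the change is 2-azido-1-hydroxyethyl in place of 4-chlorophenyl on a saturated chain carbon bound to an aromatic nitrogen. The 4-chlorophenyl leaves and a 2-azido-1-hydroxyethyl enters on the same saturated chain carbon bound to an aromatic nitrogen.

With the only aromatic-bearing chain in the set giving the lowest number in this assay, the move away from it is expected to raise the maximal response, a step beyond the scatter, estimated as a number 50 percentage points higher from compound 2 to compound 4 (beyond the scatter). Compound 4 is expected at 65%, within 25% to 140%.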

Compound 4, largest response reached (reported as maximal response), in percent of the reference or control that the assay uses: 91%
Beside the measured number, compound 4's estimate is 26 percentage points below it; the measured number falls inside the stated range.
By their numbers in this assay, from the lowest: compound 2; then compound 1; then compound 4; then compound 3.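

In this assay the chain on the aromatic nitrogen is now seen to change the maximal response on its own: 3-azido-2-hydroxypropyl in place of 4-chlorobenzyl gives a number 76 percentage points higher from compound 2 to compound 4 (beyond the scatter) with the rest of the structure unchanged. Going by these compounds alone, this is the first single-place reading, and the position clearly tolerates a non-aromatic chain. Nothing available explains the step.

Which part of the entering chain carries the step remains open. A plain propyl chain, or an amine in place of the azido group, would separate the contributions.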